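A few compounds are considered here, and "the series" means these few. Any claim that something is new, unique, unknown or untested is made for them only; others in the source may bear on it.

Measured compounds:
compound 1, `ClCc1ccccc1Cn1cnc2c(Cl)nc(Cl)nc21`, 420 nM
compound 2, `ClCc1ccccc1Cn1cnc2ncnc(Cl)c21`, 1380 nM

In a functional assay on SK-MEL-5 cells (Homo sapiens) for cytotoxicity, read by sulforhodamine B assay, with a stated time of 48 h (a higher number here means a weaker inhibitor of growth, a lower number a stronger inhibitor of growth), compound 1 holds the lowest of the two numbers; compound 2 lies higher by a step beyond the usual scatter. Compound 3, `Nc1nc(Cl)c2ncn(Cc3ccccc3CCl)c2n1`, is not yet measured; it differs from compound 1 by amino in place of chloro on an aromatic carbon. Among the compounds with values here, no measured pair shows this change, so its size is unknown. A modest weakening is expected, though within the scatter the number may also sit level with compound 1. Compound 3 is estimated at 700 nM, range 200 nM to 2500 nM, a step of a 1.7-fold higher number from compound 1 to compound 3 (0.22 log units; within the scatter).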

Compound 3, concentration for 50% growth inhibition: 8510 nM
Compound 3: the middle estimate sits 12-fold (1.08 log units) below what was measured; the measured number lies above the stated range.
By their numbers in this assay, from the lowest: compound 1; then compound 2; then compound 3.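

In this assay, the aromatic carbon between two ring nitrogen atoms proves sensitive to substitution: amino in place of chloro gives a large loss of growth inhibition (a 20-fold higher number from compound 1 to compound 3 (1.31 log units; beyond the scatter)). Compounds 1 and 2 alone gave no measure of this change at this position, and the chloro group here now appears important to the activity of compound 1. No measured data on hand account for the size of this step.

Open, going by these compounds, is whether the loss is specific to amino or extends to any replacement of chloro on this carbon. Methoxy, methylamino or fluoro at this position would separate these two readings.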